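This account rests on a few compounds, and the source may have more. Where it says the series, first, only, none or still open, it means among the compounds named here.

In a functional assay on A-375 cells (Homo sapiens) for inhibition, read by CCK-8 assay, with a stated time of 72 h, tested at 8 uM (a lower number here means less inhibition of growth, a higher number more inhibition of growth at the concentration tested), compound 1 `Nc1ccccc1NC(=O)/C=C/c1ccc(CSc2ccc(Cl)cc2)cc1` gives 48.2%, while compound 2 `Nc1ccccc1NC(=O)/C=C/c1ccc(CSc2ccc(F)cc2)cc1` gives 24.6%. The step of a number 23.6 percentage points higher from compound 2 to compound 1 (beyond the scatter) corresponds to chloro in place of fluoro on an aromatic carbon. Compound 3 `Nc1ccccc1NC(=O)c1ccc(CSc2ccc(F)cc2)cc1` rests on a different core; the difference between the two cores is not broken down here. In this assay compound 3 gives 54.3%, a number within the scatter of compound 1 and beyond the scatter of compound 2. Compound 4 `Nc1ccccc1NC(=O)c1ccc(CSc2ccc(Cl)cc2)cc1` differs from compound 3 by chloro in place of fluoro on an aromatic carbon, the same change as that between compound 2 and compound 1. Because the earlier step of a number 23.6 percentage points higher from compound 2 to compound 1 (beyond the scatter) was modest, a step in the same direction is expected here, and since compound 3 already starts higher, the expected step of a number 10.7 percentage points higher from compound 3 to compound 4 (beyond the scatter) is set somewhat smaller. Compound 4 is therefore estimated at 65%, between 50% and 80%.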

Compound 4, percent growth inhibition at one concentration: 48.6%
The estimate for compound 4 lay 16.4 percentage points above the measured number; measured number below the stated range.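

In this assay, chloro in place of fluoro did not carry over from one core to the other: the same change on two cores in this assay, a number 23.6 percentage points higher (beyond the scatter) from compound 2 to compound 1 and a number 5.7 percentage points lower (within the scatter) from compound 3 to compound 4, 29.3 percentage points apart, beyond the scatter of two such steps On the core of compound 3, the change amounts to a number 5.7 percentage points lower from compound 3 to compound 4 (within the scatter), so no difference between chloro and fluoro can be read on that core. This shows that in these two pairs the size of the step depends on the core, but it does not show why, and two pairs give no general rule for the series. The compounds shown leave open how a bromo group, a methoxy group or an amine in that same place would fare on either core. They also leave open whether the two cores would part ways again with those groups.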